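Phenethyl chromene series: hydroxy on the pendant phenyl ring

The compounds below may be only part of what the source reports. "The series", "measured", "known", "first", "only" and "open" are said of these compounds alone.

Values from a functional assay on KB cells (Homo sapiens) for cytotoxicity, read by MTT assay, with a stated time of 48 h; a higher number here means a weaker inhibitor, a lower number a stronger inhibitor:
- compound 1 `COC(=O)c1c(CCc2ccccc2)cc2c(c1O)CC(O)C(C)(C)O2`: > 40000 nM
- compound 2 `O=C1C=Cc2c(O)cc(CCc3ccccc3O)cc2OC1`: > 40000 nM
- compound 3 `CC1=CCc2c(O)cc(CCc3ccccc3)cc2OC1`: > 40000 nM

Every value for compound 3 is a limit of this assay, not a number. The same holds for compound 1 and for compound 2, so that all three sit at the limit of > 40000 nM in this assay, at which 3 of the 3 values shown sit, and no ordering among them can be read from the figures. Compound 3 therefore stands at the limit alongside the other two, with nothing to separate it from them.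

Compound 4 `CC1=CCc2c(O)cc(CCc3ccccc3O)cc2OC1` is compound 3 with one change: hydroxy in place of hydrogen on an aromatic carbon. Among the measured compounds shown here, no step between measured compounds carries this change, so its size is not known from a measurement. What the data do show is that compound 2, which already carries the hydroxyphenyl piece, is itself at the limit. On that basis no step beyond the scatter is expected in this assay, and compound 4 is expected to return a limit again rather than a number; the step from compound 3 to compound 4 is estimated as a step that the limit leaves unreadable from compound 3 to compound 4. Compound 4 is estimated at 60000 nM, within 20000 nM to 200000 nM.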

Compound 4, half-maximal inhibitory concentration: > 40000 nM
Compound 4 ended at the assay's limit; the forecaster's own chance of this, stated with the estimate: 80%; the middle value lies beyond the limit too.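

Compound 3 and compound 4 both stand at a limit of this assay rather than at a number, so the step between them cannot be read: the limit of > 40000 nM in this assay, at which 4 of the 4 values shown sit.

The compounds shown leave open what size the change from phenyl to 2-hydroxyphenyl has in this assay, and which structure in this series, if any, would give a number there.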